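The compounds below may be only part of what the source reports. "The series", "measured", "known", "first", "only" and "open" are said of these compounds alone.

Measured so far in a functional assay on NCI-H1581 cells (Homo sapiens) for inhibition, read by MTT assay, with a stated time of 48 h, tested at 10 uM; on this read-out higher numbers stand for more inhibition at the one concentration tested (going by the name of the read-out) and lower numbers for less inhibition:
compound 1, `COc1ccc(Br)cc1Nc1cc(NC(=O)Nc2c(Cl)cccc2Cl)ncn1`, gives 53.3%
compound 2, `COc1ccc(F)cc1Nc1cc(NC(=O)Nc2c(Cl)cccc2Cl)ncn1`, gives 73.1%
compound 3, `Cc1ccc(Nc2cc(NC(=O)Nc3c(Cl)cccc3Cl)ncn2)cc1F`, gives 45.3%

Compound 3 stands lowest of the three numbers in this assay. The nearest of the others lies at a number 8 percentage points lower from compound 1 to compound 3 (within the scatter), so the two are not separated; the furthest lies at a number 27.8 percentage points lower from compound 2 to compound 3 (beyond the scatter). Within the aryl on the nitrogen, a number 19.8 percentage points higher from compound 1 to compound 2 (beyond the scatter) shows that exchanging one halogen for another on an aromatic carbon can move the number in this assay.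

Compound 4, `O=C(Nc1cc(Nc2ccc(F)c(Cl)c2)ncn1)Nc1c(Cl)cccc1Cl`, differs from compound 3 in one place: 3-chloro-4-fluorophenyl in place of 3-fluoro-4-methylphenyl on a nitrogen on an aromatic ring. Within the data shown here, the steps that bear on this are the two that exchange the aryl on the nitrogen, a number 8 percentage points lower from compound 1 to compound 3 (within the scatter) and a number 27.8 percentage points lower from compound 2 to compound 3 (beyond the scatter), one within the scatter and one modest, and the halogen exchange a number 19.8 percentage points higher from compound 1 to compound 2 (beyond the scatter), also modest. Among the measured compounds shown here, no measured compound carries 3-chloro-4-fluorophenyl, so the direction cannot be read from the data; a modest step either way, or none beyond the scatter, is all that can be expected.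

Compound 4 is therefore expected to give about 50% in this assay, within a range of 35% to 65%. The estimated step of a number 4.7 percentage points higher from compound 3 to compound 4 (within the scatter) is expected to stay near the edge of the scatter.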

Compound 4, a percentage reported as inhibition, at one concentration (the size of the read-out at that concentration, not a potency): 67%
Estimate against measurement, compound 4: 17 percentage points below; measured number above the stated range.
By their numbers in this assay, from the lowest: compounds 3 and 1 (each within the scatter of the next); then compounds 4 and 2 (each within the scatter of the next).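

In this assay, a change confined to the aryl on the nitrogen on an aromatic ring, with no methoxy group on either side, gives a number 21.7 percentage points higher from compound 3 to compound 4 (beyond the scatter), so this position moves the number even when the two aryls have the same heavy-atom count and differ only in their substituents. Set against the 5-fluoro-2-methoxyphenyl group, 3-chloro-4-fluorophenyl gives a number 6.1 percentage points lower from compound 2 to compound 4 (within the scatter), whereas against 5-bromo-2-methoxyphenyl it gives a number 13.7 percentage points higher from compound 1 to compound 4 (beyond the scatter), which shows that among these four compounds a methoxy group on this aryl is not needed for a number in the range of compound 2. Nothing measured on these compounds accounts for these differences.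

Still open, as far as these compounds go, is whether the chlorine of the 3-chloro-4-fluorophenyl group can give way to a nitrile or a trifluoromethyl group with the number held, and whether a morpholine or a carboxylic acid on this aryl leaves the number higher, lower or level. From the compounds shown here alone, with a read-out at one concentration, it also remains open whether compound 2 and compound 4 would separate in potency.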